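Hydroxamic acid series: aryl swap on the shared core

The source may report more compounds than this note shows. Statements on the series, on what has been measured and on what is new or still open speak of the compounds shown alone.

Measured so far:
compound 1 `O=C(NO)c1ccc(NCc2nc(-c3ccc(Cl)cc3)nn2-c2ccccc2)cc1` — 67.2%
compound 2 `CNC(=O)c1ccc(NCc2nc(-c3ccccc3)nn2-c2ccccc2)cc1` — -3.6%

In an assay on Sf9 cells for inhibition of protein deacetylase HDAC6 (Homo sapiens), read by fluorescence, with a stated time of 40 min, tested at 100 nM (on this read-out lower numbers stand for less inhibition and higher numbers for more inhibition at the one concentration tested (going by the name of the read-out)), compound 1 gives 67.2%, the higher of the two numbers, and compound 2 gives -3.6%, a gap beyond the scatter. Among the compounds with values here, compound 2 differs from compound 1 in more than one place, so no single step is drawn between them.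

Compound 3 `Cc1ccc(-c2nc(CNc3ccc(C(=O)NO)cc3)n(-c3ccccc3)n2)o1` is not yet measured. Against compound 1 it shows (5-methylfuran-2-yl in place of 4-chlorophenyl on an aromatic carbon). Within the data shown here, no measured pair isolates this change, so a moderate downward step in this assay is expected, a number 12.2 percentage points lower from compound 1 to compound 3 (beyond the scatter). Compound 3 is estimated at 55%, within 30% to 78%.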

Compound 3, a percentage reported as inhibition, at one concentration (the size of the read-out at that concentration, not a potency): 60.7%
For compound 3 the middle estimate is 5.7 percentage points below the measured one, within the range that was stated.
By their numbers in this assay, from the lowest: compound 2; then compounds 3 and 1 (each within the scatter of the next).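

In this assay, 5-methylfuran-2-yl in place of 4-chlorophenyl on an aromatic carbon of the shared core gives a number 6.5 percentage points lower from compound 1 to compound 3 (within the scatter). For this pair, a five-membered aromatic ring with one oxygen thus reads the same as a chlorine-bearing six-membered carbon ring at this position. Nothing on hand gives a reason for this result.

From the compounds shown here alone, whether an open chain or an amine at this carbon would read the same remains open. Also open, going by these compounds, is how the series responds to a carboxylic acid in place of the hydroxamic acid, with the rest of compound 1 unchanged.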